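The compounds below may be only part of what the source reports. "The series", "measured", "known", "first", "only" and "open" are said of these compounds alone.

Compound 1 `C/C(=C\C(=O)Nc1ccccc1OCCCC(=O)O)c1ccc2c(ccn2Cc2ccc(C)cc2)c1` and compound 2 `CCCCC(c1ccccc1)n1ccc2cc(/C(C)=C/C(=O)Nc3ccccc3OCCCC(=O)O)ccc21` share one core and differ only in the group carried on the aromatic nitrogen. In an assay on Prostate gland for inhibition of steroid 5-alpha-reductase (Rattus norvegicus) (a lower number here means a stronger inhibitor, a higher number a weaker inhibitor), compound 1 gives 88 nM, and in this assay compound 2 gives 9.8 nM. For the measured compounds named here, the single step between them, a 9.0-fold lower number from compound 1 to compound 2 (0.95 log units; beyond the scatter), is the only step measured so far, and it places compound 2 at the lowest number of the two, with compound 1 the nearest neighbour.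

Compound 3 `C/C(=C\C(=O)Nc1ccccc1OCCCC(=O)O)c1ccc2c(ccn2C(c2ccccc2)c2ccncc2)c1` is not yet measured. It keeps the substituent pattern of compound 2 and changes it in one place: pyridin-4-yl in place of butyl on a saturated chain carbon bound to an aromatic carbon and an aromatic nitrogen. Going by the values given here, no measured step touches this position, and the step from compound 1 to compound 2 speaks only to the replacement of the whole group on the aromatic nitrogen, not to an exchange within it. Among the compounds with values here, there is therefore no direct precedent, and an estimate for compound 3 in this assay must lean on compound 2 alone, with wide bounds. Compound 3 is expected to give about 25 nM, with a range of 6 nM to 100 nM. This corresponds to an expected step of a 2.6-fold higher number from compound 2 to compound 3 (0.41 log units; beyond the scatter), which could fall on either side of the scatter.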

Compound 3, half-maximal inhibitory concentration: 26 nM
Estimate against measurement, compound 3: 1.0-fold (0.02 log units) below; low and high end bracket the measured number.
By their numbers in this assay, from the lowest: compound 2; then compound 3; then compound 1.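

In this assay, for the compounds shown here, the earlier compounds changed the whole group on the aromatic nitrogen, whereas this result is the first exchange within that group, on a saturated chain carbon bound to an aromatic carbon and an aromatic nitrogen. Pyridin-4-yl in place of butyl gives a 2.7-fold higher number from compound 2 to compound 3 (0.42 log units; beyond the scatter), so an open chain and a six-membered aromatic ring with 1 hetero atom can be compared directly at this place, and butyl gives the lower number of the two. Nothing available explains this modest step.

The compounds shown cannot separate the effect of the ring from that of its nitrogen, a question that a second phenyl or a pyridin-3-yl in the same place would address. They also leave open how the number would respond to a chain other than butyl, such as propyl or hexyl, or to a chain ending in an amine.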